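The source may hold more compounds than are shown below. What is called first, only, known or untested is meant among the compounds shown, and "the series" means these compounds.

Measured in a functional assay on MDA-MB-231 cells (Homo sapiens) for cytotoxicity, read by sulforhodamine B assay; on this read-out lower numbers stand for stronger inhibition of growth and higher numbers for weaker inhibition of growth:
- compound 1 `O=C(NCCCCCNC(=O)C1=NO[C@]2(C=C(Br)C(=O)[C@@H](Br)[C@@H]2O)C1)C1=NO[C@]2(C=C(Br)C(=O)[C@@H](Br)[C@@H]2O)C1`: 1600 nM
- compound 2 `COC1=C(Br)[C@H](O)[C@@]2(C=C1Br)CC(C(=O)NCCCCCNC(=O)C1=NO[C@]3(C=C(Br)C(OC)(OC)[C@@H](Br)[C@@H]3O)C1)=NO2`: 4200 nM

Compound 1 holds the lower of the two numbers, and its gap to compound 2 lies beyond the scatter. Compound 3 `O=C(NCCCCCNC(=O)C1=NO[C@]2(C=C(Br)C(=O)[C@H](Br)[C@@H]2O)C1)C1=NO[C@]2(C=C(Br)C(=O)[C@H](Br)[C@@H]2O)C1` is a stereoisomer of compound 1: the two compounds have the same atoms and bonds and differ only in configuration as drawn: 2 of 6 stereo elements differ; a stereocentre at a saturated ring carbon is drawn S in compound 1 and R in compound 3; a stereocentre at a saturated ring carbon is drawn S in compound 1 and R in compound 3. For the measured compounds named here, no measured pair in this assay isolates a change of configuration, so the direction is uncertain. A modest weakening of growth inhibition is expected, possibly none beyond the scatter.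

The expected step is a 1.6-fold higher number from compound 1 to compound 3 (0.19 log units; within the scatter).

The estimated value for compound 3 is 2500 nM, with an expected range of 1000 nM to 6500 nM.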

Compound 3, concentration for 50% growth inhibition: 1700 nM
For compound 3 the middle estimate is 1.5-fold (0.17 log units) above the measured one; the range from low to high includes it.
By their numbers in this assay, from the lowest: compounds 1 and 3 (each within the scatter of the next); then compound 2.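

In this assay, moving the two stereocentres at saturated ring carbons from S to R gives a 1.1-fold higher number from compound 1 to compound 3 (0.03 log units; within the scatter), so this read-out does not tell the two configurations apart. This is the first pair in the series to isolate configuration alone: the fact that compounds 1 and 3 differ only in the configuration as drawn

Going by these compounds, whether the remaining stereo elements are equally silent stays open. Also open, on these data alone, is what a longer chain, or an amine on the shared core, would do to growth inhibition in this assay.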